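Chloro added to the core of compound 2

This account rests on a few compounds, and the source may have more. Where it says the series, first, only, none or still open, it means among the compounds named here.

In a functional assay on P388 cells (Mus musculus) for antiproliferative activity, read by colorimetric assay and MTT assay (on this read-out higher numbers stand for weaker inhibition and lower numbers for stronger inhibition), compound 2 (`Nc1ccc(S(=O)(=O)Nc2cccc3cc[nH]c23)cc1`) stands at 14 ug/mL as the higher of two numbers, while compound 1 (`Cc1ccc(S(=O)(=O)Nc2cccc3cc(Cl)[nH]c23)cc1`) gives 0.14 ug/mL and lies beyond the scatter from it. Compound 3 (`Nc1ccc(S(=O)(=O)Nc2cccc3cc(Cl)[nH]c23)cc1`) is compound 2 with chloro in place of hydrogen on an aromatic carbon. Among the measured compounds shown here, no single-place step has been measured, so the only guide is compound 1, which carries the same chloro at 0.14 ug/mL but also differs in another group. A fall beyond the scatter is expected, estimated as a 23-fold lower number from compound 2 to compound 3 (1.37 log units; beyond the scatter) toward stronger inhibition. In this assay compound 3 is estimated at 0.6 ug/mL with 0.1 ug/mL as lower and 4 ug/mL as upper end.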

Compound 3, half-maximal inhibitory concentration: 2.2 ug/mL
Compound 3: the middle estimate sits 3.7-fold (0.56 log units) below what was measured; the range from low to high includes it.
By their numbers in this assay, from the lowest: compound 1; then compound 3; then compound 2.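

In this assay, chloro in place of hydrogen on an aromatic carbon next to the ring nitrogen now has a step of its own (a 6.4-fold lower number from compound 2 to compound 3 (0.80 log units; beyond the scatter)), toward stronger inhibition. With chloro held in place, amino in place of methyl gives (a 16-fold higher number from compound 1 to compound 3 (1.20 log units; beyond the scatter)), so chloro alone does not account for the low number of compound 1. Nothing measured here gives a reason for either step.

On these data alone, whether fluoro, bromo or a methyl group on the same carbon would match chloro remains open. Also open, as far as these compounds go, is whether the methyl and amino groups would differ in the same direction with hydrogen at that carbon.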